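Varying the Sulfonamide Nitrogen Substituent on a Shared Core

The compounds below may be only part of what the source reports. "The series", "measured", "known", "first", "only" and "open" are said of these compounds alone.

In a functional assay on the whole organism (trachea) with Rattus norvegicus as the target (a higher number here means a larger maximal response, a lower number a smaller maximal response), compound 1 `CC1(C)C=C(n2ccccc2=O)c2cc(S(=O)(=O)N=[N+]=[N-])ccc2O1` gives 77.2%, and compound 2 `CC1(C)C=C(n2ccccc2=O)c2cc(S(=O)(=O)Nc3ccc([N+](=O)[O-])cc3)ccc2O1` gives 75.6%. Compound 2 holds the lowest of the two numbers, with compound 1 sitting within the scatter of it. Within the data shown here, the only measured step, a number 1.6 percentage points lower from compound 1 to compound 2 (within the scatter), alters the same sulfonyl sulfur that compound 3 `CN(c1ccccc1)S(=O)(=O)c1ccc2c(c1)C(n1ccccc1=O)=CC(C)(C)O2` now alters again, through (methyl(phenyl)amino in place of (4-nitrophenyl)amino on a sulfonyl sulfur). Because that step, a number 1.6 percentage points lower from compound 1 to compound 2 (within the scatter), stayed within the scatter, no step beyond the scatter is expected here either. Compound 3 is therefore estimated at 76%, with a range from 62% to 88%. The expected step is a number 0.4 percentage points higher from compound 2 to compound 3 (within the scatter).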

Compound 3, largest response reached (Emax), in percent of the reference or control that the assay uses: 86.5%
Compound 3: the middle estimate sits 10.5 percentage points below what was measured; the measured number falls inside the stated range.
By their numbers in this assay, from the lowest: compounds 2, 1 and 3 (each within the scatter of the next, the first and the last beyond it).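

In this assay, among these compounds, the sulfonyl sulfur position proved able to move the maximal response: methyl(phenyl)amino in place of (4-nitrophenyl)amino gives a number 10.9 percentage points higher from compound 2 to compound 3 (beyond the scatter), the first step here to pass the scatter. Methyl(phenyl)amino in place of azido, by contrast, gives a number 9.3 percentage points higher from compound 1 to compound 3 (within the scatter), so this substituent is separated from only one of the two earlier ones. Nothing available here accounts for this difference.

The change adds the methyl and removes the nitro group at once, and their separate contributions remain unresolved. Going by these compounds, whether plain phenylamino, a morpholine or a longer alkyl chain on the sulfonyl sulfur would give a similar maximal response also stays open.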